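The compounds below may be only part of what the source reports. "The series", "measured", "known", "first", "only" and "open" are said of these compounds alone.

Measured compounds:
- compound 1 `Nc1scc(CN2CCN(c3ccccc3C(F)(F)F)CC2)c1C(=O)c1ccc(Cl)cc1`: 0%
- compound 2 `Nc1scc(CN2CCN(c3ccc(Cl)c(C(F)(F)F)c3)CC2)c1C(=O)c1ccc(Cl)cc1`: 3%
- compound 3 `Nc1scc(CN2CCN(c3ccncc3)CC2)c1C(=O)c1ccc(Cl)cc1`: 2%

All three were tested in an assay on CHO cells for displacement of a labelled ligand from adenosine receptor A3 (Homo sapiens), read by scintillation counting, with a stated time of 120 min, tested at 10 uM; on this read-out lower numbers stand for less inhibition and higher numbers for more inhibition at the one concentration tested (going by the name of the read-out). On the numbers shown, compound 3 holds the second highest of the three values, but its nearest neighbour is compound 2 at a number 1 percentage points lower from compound 2 to compound 3 (within the scatter), and its furthest is compound 1 at a number 2 percentage points higher from compound 1 to compound 3 (within the scatter), so none of the three is separated from any other beyond the scatter. The step from compound 1 to compound 2, a number 3 percentage points higher from compound 1 to compound 2 (within the scatter), is likewise within the scatter.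

Compound 4 `Nc1scc(CN2CCN(c3cccc(F)c3F)CC2)c1C(=O)c1ccc(Cl)cc1` has not yet been measured. It differs from compound 3 at the same place that varies among the three measured compounds: 2,3-difluorophenyl in place of pyridin-4-yl on an amine nitrogen in a ring. Going by the values given here, the steps that bear on this change are those at the amine nitrogen in a ring, namely a number 2 percentage points higher from compound 1 to compound 3 (within the scatter) and a number 1 percentage points lower from compound 2 to compound 3 (within the scatter), both within the scatter; three different groups at this position have given essentially the same read-out. Compound 4 is therefore expected to show no step beyond the scatter, no change at the digits printed from compound 3 to compound 4 (within the scatter), in this assay. Compound 4 is estimated at 2%, with a range from -5% to 10%.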

Compound 4, a percentage reported as inhibition, at one concentration (the size of the read-out at that concentration, not a potency): 0%
For compound 4 the middle estimate is 2 percentage points above the measured one, and the stated range covers the measured number.
By their numbers in this assay, from the lowest: compounds 1, 4, 3 and 2 (each within the scatter of the next).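

In this assay the 2,3-difluorophenyl group gives a number 2 percentage points lower from compound 3 to compound 4 (within the scatter) when it takes the place of pyridin-4-yl on the amine nitrogen in a ring. Set against the other two groups at this place, it gives a number 3 percentage points lower from compound 2 to compound 4 (within the scatter) and no change at the digits printed from compound 1 to compound 4 (within the scatter) so all four groups now lie within the scatter of one another. Replacing pyridin-4-yl with a carbon-only aromatic ring bearing two fluorines, with the loss of the one hydrogen-bond acceptor in the group, therefore does not separate compound 4 from the others, and nothing available here offers an explanation for this flat result.

With only aromatic rings at this place and one concentration behind each value, the compounds shown leave open whether a group of another kind, such as a cyclohexyl ring, an acetyl group or a benzoic acid, would move the read-out beyond the scatter. They also leave open what a change elsewhere on the shared core would do, for example a methoxy group in place of the chlorine on the 4-chlorophenyl group.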